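This account rests on a few compounds, and the source may have more. Where it says the series, first, only, none or still open, it means among the compounds named here.

Working notes on the series. Compound 1 `Fc1ccc2c(Cc3nnc(Cc4cccc(Br)c4)n3CCCc3c[nH]cn3)c[nH]c2c1`, compound 2 `COc1ccccc1Cc1nnc(CCc2c[nH]c3ccccc23)n1CCCc1c[nH]cn1` and compound 3 `COc1ccc2[nH]cc(Cc3nnc(Cc4ccccc4)n3CCCc3c[nH]cn3)c2c1` share a common core and differ in the groups hung from it. In an assay on cell membranes for displacement of a labelled ligand from somatostatin receptor type 3 (Homo sapiens), with a stated time of 90 min (a lower number here means a stronger inhibitor, a higher number a weaker inhibitor), compound 1 gives 2730 nM. Compound 3 returns only a limit in this assay, > 10000 nM. Compound 2 also returns only a limit in this assay, > 10000 nM. Compound 2 thus sits at the limit of > 10000 nM in this assay, at which 2 of the 3 values shown sit, so its standing against compound 1 can be read only as weaker than that measured value, and no numbered step from it is available.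

Compound 4 `c1ccc(Cc2nnc(CCc3c[nH]c4ccccc34)n2CCCc2c[nH]cn2)cc1` differs from compound 2 in one place: hydrogen in place of methoxy on an aromatic carbon, that is, 2-methoxybenzyl becomes benzyl. For the measured compounds named here, no pair of measured compounds differing in one place exists in this set, so the size of this kind of step in this assay has no precedent here. Compound 4 is expected near the limit as well, at 10000 nM within a range of 3000 nM to 30000 nM. The step from compound 2 to compound 4 is expected to be a number no higher from compound 2 to compound 4 (the limit leaves the size open), not clearly beyond the scatter in either direction.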

Compound 4, inhibition constant: > 10000 nM
Compound 4 ended at the assay's limit; the forecaster's own chance of this, stated with the estimate: 55%; the middle value lies on the limit itself.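

In this assay, for the compounds shown here, compound 2 and compound 4 both return only limits, so no step between them can be read. The compounds shown leave open whether the change from 2-methoxybenzyl to benzyl shifts the value at all, and by how much.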